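Bromo for methyl in a small antiproliferative series

The source may report more compounds than this note shows. Statements on the series, on what has been measured and on what is new or still open speak of the compounds shown alone.

Measured so far in a functional assay on MCF7 cells (Homo sapiens) for antiproliferative activity, read by MTT assay, with a stated time of 48 h (a higher number here means a weaker inhibitor, a lower number a stronger inhibitor), for three compounds
- compound 1 `Cc1ccc(NCc2cn(-c3ccccc3)nc2-c2ccc(Cl)cc2)cc1` gives 3110 nM
- compound 2 `Cc1ccc(NCc2cn(-c3ccccc3)nc2-c2ccc(C)cc2)cc1` gives 7260 nM
- compound 3 `Cc1ccc(-c2nn(-c3ccccc3)cc2CNc2ccc(Br)cc2)cc1` gives 6890 nM

Compound 2 stands at the high end of the three numbers, with a 1.1-fold lower number from compound 2 to compound 3 (0.02 log units; within the scatter) as the gap to its nearest neighbour and compound 1 lower. The change to compound 4 `Cc1ccc(NCc2cn(-c3ccccc3)nc2-c2ccc(Br)cc2)cc1` is bromo in place of methyl on an aromatic carbon and reads 4-methylphenyl to 4-bromophenyl. Within the data shown here, the group that changes here is the one that also changes in a 2.3-fold higher number from compound 1 to compound 2 (0.37 log units; beyond the scatter) and that modest step is the closest guide. The same bromo in place of methyl on the other 4-methylphenyl group gives a 1.1-fold lower number from compound 2 to compound 3 (0.02 log units; within the scatter) and so argues for caution. A step toward a lower number is therefore expected in this assay at about the edge of the scatter, and no step beyond the scatter remains possible. The expected step is a 1.8-fold lower number from compound 2 to compound 4 (0.26 log units; within the scatter) on this reasoning. The estimated value for compound 4 is 4000 nM with an expected range of 2200 nM to 7500 nM in this assay.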

Compound 4, half-maximal inhibitory concentration: 5380 nM
For compound 4 the middle estimate is 1.3-fold (0.13 log units) below the measured one; low and high end bracket the measured number.
By their numbers in this assay, from the lowest: compounds 1, 4, 3 and 2 (each within the scatter of the next, the first and the last beyond it).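

In this assay, the 4-methylphenyl to 4-bromophenyl change gives a 1.3-fold lower number from compound 2 to compound 4 (0.13 log units; within the scatter) and so does not separate bromo from methyl at this position, in line with the same swap on the other 4-methylphenyl group, which gives a 1.1-fold lower number from compound 2 to compound 3 (0.02 log units; within the scatter). At the same position, a 1.7-fold higher number from compound 1 to compound 4 (0.24 log units; within the scatter) does not separate bromo from chloro either, so bromo lies within the scatter of both groups, even though chloro and methyl are separated by a 2.3-fold higher number from compound 1 to compound 2 (0.37 log units; beyond the scatter). Nothing measured here offers an explanation for these values.

With three groups at this position and steps this small, no ranking beyond chloro over methyl can be drawn. On these data alone, how an amine, a carboxylic acid or a methoxy group on this aromatic carbon would read remains open.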